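Bromo in place of chloro on the side-chain aromatic ring

The source may hold more compounds than are shown below. What is called first, only, known or untested is meant among the compounds shown, and "the series" means these compounds.

In a functional assay on HT-29 cells (Homo sapiens) for inhibition, read by MTT assay, with a stated time of 3 days (on this read-out lower numbers stand for stronger inhibition and higher numbers for weaker inhibition), compound 1 `C/C=C/COc1cc(/C=C\c2cc(OC)c(OC)c(OC)c2)ccc1OC` gives 161000 nM, compound 2 `COc1ccc(/C=C/CCCOc2cc(/C=C\c3cc(OC)c(OC)c(OC)c3)ccc2OC)cc1` gives 47000 nM and compound 3 `COc1ccc(/C=C\c2cc(OC)c(OC)c(OC)c2)cc1OCCC/C=C/c1ccc(Cl)cc1` gives 18000 nM. Compound 3 therefore holds the lowest of the three numbers, and its steps to both others lie beyond the scatter.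

The next compound, compound 4 `COc1ccc(/C=C\c2cc(OC)c(OC)c(OC)c2)cc1OCCC/C=C/c1ccc(Br)cc1`, has bromo in place of chloro on an aromatic carbon, para to a large group: bromo in place of chloro on an aromatic carbon.

The most relevant measured change is a 2.6-fold lower number from compound 2 to compound 3 (0.42 log units; beyond the scatter), with chloro in place of methoxy. The larger replacements of prop-1-en-1-yl, a 3.4-fold lower number from compound 1 to compound 2 (0.53 log units; beyond the scatter) and an 8.9-fold lower number from compound 1 to compound 3 (0.95 log units; beyond the scatter), exchange much more of the structure and bear on this change less directly. Among the measured compounds shown here, no measured step exchanges one halogen for another, so the direction remains open, and the modest size of the step from methoxy to chloro argues against a large shift. The estimated step is a 1.1-fold lower number from compound 3 to compound 4 (0.05 log units; within the scatter), which is not expected to exceed the scatter. In this assay, compound 4 is expected at 16000 nM, with an estimated range of 6000 nM to 45000 nM.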

Compound 4, half-maximal inhibitory concentration: 11000 nM
The estimate for compound 4 lay 1.5-fold (0.16 log units) above the measured number; the range from low to high includes it.
By their numbers in this assay, from the lowest: compounds 4 and 3 (each within the scatter of the next); then compound 2; then compound 1.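

In this assay, among the compounds shown here, the first exchange of one halogen for another on this aromatic carbon gives a 1.6-fold lower number from compound 3 to compound 4 (0.21 log units; within the scatter) and so does not separate bromo from chloro. Bromo in place of methoxy on the same carbon gives a 4.3-fold lower number from compound 2 to compound 4 (0.63 log units; beyond the scatter) and thus a step beyond the scatter, which compound 3 also showed with chloro; at this position, both halogens part from methoxy in the same direction. For the compounds shown here, replacing prop-1-en-1-yl with the whole bromophenyl-bearing chain gives a 15-fold lower number from compound 1 to compound 4 (1.17 log units; beyond the scatter) and is the only step rated large.

On these data alone, whether fluoro, iodo, a nitrile or an amine on this ring carbon would follow bromo and chloro remains open, as does the effect of a shorter or longer chain. Nothing shown gives a reason for any of these steps.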